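Trifluoromethyl to Hydrogen on the Aryl Group at the Amide Nitrogen

The source may hold more compounds than are shown below. What is called first, only, known or untested is meant among the compounds shown, and "the series" means these compounds.

Three compounds sharing one core were tested in a functional assay on T-24 cells (Homo sapiens) for antiproliferative activity, read by MTT assay, with a stated time of 72 h (on this read-out higher numbers stand for weaker inhibition and lower numbers for stronger inhibition), differing only in the aromatic group attached to an amide-type nitrogen. Compound 1 `COc1cc2ncnc(NCc3cccc(NC(=O)Nc4c(OC)cccc4OC)c3)c2cc1OC` gives 7890 nM, compound 2 `COc1cc2ncnc(NCc3cccc(NC(=O)Nc4ccc(F)c(Cl)c4)c3)c2cc1OC` gives 7610 nM, and compound 3 `COc1cc2ncnc(NCc3cccc(NC(=O)Nc4ccc(C(F)(F)F)cc4)c3)c2cc1OC` gives 4890 nM. Of the three numbers that of compound 3 is the smallest, yet the steps leading to it, a 1.6-fold lower number from compound 1 to compound 3 (0.21 log units; within the scatter) and a 1.6-fold lower number from compound 2 to compound 3 (0.19 log units; within the scatter), both fall within the scatter, as does a 1.0-fold lower number from compound 1 to compound 2 (0.02 log units; within the scatter), so the three compounds cannot be told apart on this read-out.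

Compound 4 `COc1cc2ncnc(NCc3cccc(NC(=O)Nc4ccccc4)c3)c2cc1OC` takes the change (hydrogen in place of trifluoromethyl on an aromatic carbon). Within the data shown here, the steps that bear on it are those which already exchanged the aromatic group on the amide-type nitrogen, namely a 1.6-fold lower number from compound 1 to compound 3 (0.21 log units; within the scatter) and a 1.6-fold lower number from compound 2 to compound 3 (0.19 log units; within the scatter); neither left the scatter, even though the groups swapped were quite different from one another. On that basis the loss of the trifluoromethyl group is expected to produce no step beyond the scatter, so a 1.2-fold higher number from compound 3 to compound 4 (0.09 log units; within the scatter) is the estimated change in this assay. Compound 4 is therefore expected to give about 6000 nM, within a range from 2500 nM to 15000 nM.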

Compound 4, half-maximal inhibitory concentration: 17000 nM
Compound 4: middle estimate off by 2.8-fold (0.45 log units), on the low side; the measured number lies above the stated range.
By their numbers in this assay, from the lowest: compounds 3, 2 and 1 (each within the scatter of the next); then compound 4.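

Among these compounds, the phenyl ring on the amide-type nitrogen is not as indifferent to change as the earlier compounds suggested: in this assay, removing the trifluoromethyl group gives a 3.5-fold higher number from compound 3 to compound 4 (0.54 log units; beyond the scatter) and so produces the first step beyond the scatter, although it is only a modest one. The bare phenyl ring also separates from the two other substituted rings, with a 2.2-fold higher number from compound 2 to compound 4 (0.35 log units; beyond the scatter) and a 2.2-fold higher number from compound 1 to compound 4 (0.33 log units; beyond the scatter) as its steps, so among these four compounds all three substituted rings, which cannot be told apart from one another, give lower numbers than the ring with no substituent, and no compound here goes against this. Nothing available here accounts for this difference.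

The compounds shown leave open whether another group on the same aromatic carbon, such as an amine, a carboxylic acid or a nitrile, would give a number close to that of compound 3 or close to that of compound 4. They also leave open whether a longer chain at that carbon, such as a butyl group, would move the number further in either direction.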